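Chain extension on the nitrogen substituent of compound 3

A few compounds are considered here, and "the series" means these few. Any claim that something is new, unique, unknown or untested is made for them only; others in the source may bear on it.

Measured compounds:
Compound 1 `CCCCn1ccc2cc(/C(C)=C/C(=O)Nc3ccccc3OCCCC(=O)O)ccc21` gives 43 nM in an assay on Prostate gland for inhibition of steroid 5-alpha-reductase (Rattus norvegicus); a higher number here means a weaker inhibitor, a lower number a stronger inhibitor.
Compound 2 `C/C(=C\C(=O)Nc1ccccc1OCCCC(=O)O)c1ccc2c(ccn2CC(C)C)c1` gives 160 nM in this assay.
Compound 3 `CCCC(CC)n1ccc2cc(/C(C)=C/C(=O)Nc3ccccc3OCCCC(=O)O)ccc21` gives 9.3 nM in this assay.

Compound 3 stands lowest of the three numbers in this assay; its nearest neighbour is compound 1, and compound 2 lies furthest away. The two steps into compound 3 both point the same way: a 4.6-fold lower number from compound 1 to compound 3 (0.66 log units; beyond the scatter) and a 17-fold lower number from compound 2 to compound 3 (1.24 log units; beyond the scatter). For the measured compounds named here, the one step that removes rather than adds chain length at the saturated carbon bound to the aromatic nitrogen runs the other way, a 3.7-fold higher number from compound 1 to compound 2 (0.57 log units; beyond the scatter).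

Compound 4 `CCCCC(CC)n1ccc2cc(/C(C)=C/C(=O)Nc3ccccc3OCCCC(=O)O)ccc21` differs from compound 3 by methyl in place of hydrogen on a saturated chain carbon, four bonds along the chain from an aromatic nitrogen. Going by the values given here, no measured step changes this position; the steps above all alter the carbon bound to the aromatic nitrogen, and they show that lengthening there lowers the number, while branching into an isobutyl raises it. The change here is a single carbon further out on the chain, so the expectation is a step no larger than the scatter, leaning if anything towards a slightly lower number: a 1.3-fold lower number from compound 3 to compound 4 (0.12 log units; within the scatter) is the expected step. Compound 4 is estimated at 7 nM in this assay, with a range from 3 nM to 20 nM.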

Compound 4, half-maximal inhibitory concentration: 7.1 nM
Compound 4: the middle estimate sits 1.0-fold (0.01 log units) below what was measured; low and high end bracket the measured number.
By their numbers in this assay, from the lowest: compounds 4 and 3 (each within the scatter of the next); then compound 1; then compound 2.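

Methyl in place of hydrogen on a saturated chain carbon, four bonds along the chain from an aromatic nitrogen, gives a 1.3-fold lower number from compound 3 to compound 4 (0.12 log units; within the scatter) in this assay and is the first reading at this position, which shows that the chain carries this extra carbon with no change that can be told from scatter. The gains on the other nitrogen substituents stay in place with 1-ethylpentyl, which gives a 23-fold lower number from compound 2 to compound 4 (1.35 log units; beyond the scatter) against isobutyl and a 6.1-fold lower number from compound 1 to compound 4 (0.78 log units; beyond the scatter) against butyl, so the large step from isobutyl and the modest one from butyl both hold for this longer group as well. No evidence beyond these numbers bears on this result.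

The compounds shown leave open whether a longer chain at this position, or an amine or a hydroxyl at the chain end, would stay within the scatter of compound 4 or move the number beyond it. Also open, going by these compounds, is whether a propyl could replace the ethyl on the saturated chain carbon bound to the aromatic nitrogen with the same outcome.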